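The source may report more compounds than this note shows. Statements on the series, on what has been measured and on what is new or still open speak of the compounds shown alone.

Compounds measured so far: compound 1 `CCCc1cc(N2CCCC2)c2cc(NC(=O)/C=C/c3ccc(C(F)(F)F)cc3)ccc2n1` with 17 nM; compound 2 `Nc1cc(C2CCC2)nc2ccc(NC(=O)/C=C/c3ccc(C(F)(F)F)cc3)cc12` with 2 nM.

In an assay on isolated protein for displacement of a labelled ligand from melanin-concentrating hormone receptor 1 (Homo sapiens) (a lower number here means a stronger inhibitor, a higher number a weaker inhibitor), compound 1 gives the higher of the two numbers, and its gap to compound 2 lies beyond the scatter. Compound 3 `CCCc1cc(OC)c2cc(NC(=O)/C=C/c3ccc(C(F)(F)F)cc3)ccc2n1` differs from compound 1 by methoxy in place of pyrrolidin-1-yl on an aromatic carbon. For the measured compounds named here, no measured pair shows this change, so the pair of known values gives no direct guide. A moderate rise in the number is expected, rather than none or a large one. Compound 3 is expected at 40 nM, within 10 nM to 160 nM, a step of a 2.4-fold higher number from compound 1 to compound 3 (0.37 log units; beyond the scatter).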

Compound 3, half-maximal inhibitory concentration: 26 nM
The estimate for compound 3 lay 1.5-fold (0.19 log units) above the measured number; low and high end bracket the measured number.
By their numbers in this assay, from the lowest: compound 2; then compounds 1 and 3 (each within the scatter of the next).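

In this assay, methoxy in place of pyrrolidin-1-yl on this aromatic carbon, opposite the ring nitrogen, gives a 1.5-fold higher number from compound 1 to compound 3 (0.18 log units; within the scatter). For this pair, then, the five-membered non-aromatic ring is not needed to keep the number in the same range. No available evidence explains why the two groups read alike.

Compound 2 differs from compound 1 in more than one place, so it cannot separate the contribution of this position from that of the other change. On these data alone, whether an ethoxy group or a morpholine ring on this carbon would also read alike remains open.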